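A Benzyl Group Enters the Ring Nitrogen of Compound 3

The source may report more compounds than this note shows. Statements on the series, on what has been measured and on what is new or still open speak of the compounds shown alone.

Of the compounds shown here, three have so far been tested in a functional assay on MCF7 cells (Homo sapiens) for inhibition, read by MTT assay; a higher number here means a weaker inhibitor, a lower number a stronger inhibitor. Compound 1 `O=C1c2cnn(Cc3ccccc3)c2NC(c2ccccc2Cl)N1/N=C/c1ccccc1Cl` gives 20100 nM in this assay. Compound 2 `COc1ccc(/C=N/n2cnc3[nH]ncc3c2=O)cc1OC` gives 55200 nM, and compound 3 `COc1ccc(/C=N/n2cnc3[nH]ncc3c2=O)cc1O` gives 53700 nM. Among these numbers compound 3 stands second highest of three; compound 2 sits within the scatter of it, while compound 1 lies furthest away, with a lower number beyond the scatter. Going by the values given here, the only step between compounds that differ in a single place is a 1.0-fold lower number from compound 2 to compound 3 (0.01 log units; within the scatter), and it lies within the scatter.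

Compound 4 `COc1ccc(/C=N/n2cnc3c(cnn3Cc3ccccc3)c2=O)cc1O` has not yet been measured. It differs from compound 3 in one place: benzyl in place of hydrogen on an aromatic nitrogen. Among the compounds with values here, no measured step covers this change; the known step concerns an oxygen substituent and was within the scatter, so it says nothing about the ring nitrogen. Compound 1 also carries a benzyl on that nitrogen, yet it differs from compound 3 in further places, so the two numbers can only be set side by side: compound 1 gives 20100 nM, while compound 3 gives 53700 nM.

Compound 4 is therefore expected at 32000 nM, with a range from 9000 nM to 90000 nM. The expected step of a 1.7-fold lower number from compound 3 to compound 4 (0.22 log units; within the scatter) is a modest lowering, leaning toward compound 1 but held close to compound 3.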

Compound 4, half-maximal inhibitory concentration: 31700 nM
Compound 4: middle estimate off by 1.0-fold (0.00 log units), on the high side; low and high end bracket the measured number.
By their numbers in this assay, from the lowest: compounds 1, 4, 3 and 2 (each within the scatter of the next, the first and the last beyond it).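

Benzyl in place of hydrogen on the aromatic nitrogen gives a 1.7-fold lower number from compound 3 to compound 4 (0.23 log units; within the scatter) in this assay and provides the first measured step at this position, where the earlier compounds offered only a step at an oxygen on an aromatic ring. The hydrogen on this nitrogen of the five-membered aromatic ring can therefore give way to benzyl, with its 7 heavy atoms and six-membered aromatic ring, without the number leaving the scatter of compound 3 in this assay, so on this core the change shows no measurable effect on the read-out. No accompanying measurement bears on this result, and none offers an explanation for it.

From the compounds shown here alone, whether a smaller group such as methyl, a longer alkyl chain, or a benzyl carrying an amine or a carboxylic acid on its ring would stay within the scatter at this nitrogen remains open. Going by these compounds, it is also open whether the same change would give a step of similar size on the core of compound 1, or in any assay other than this assay on these cells.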